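The source may report more compounds than this note shows. Statements on the series, on what has been measured and on what is new or still open speak of the compounds shown alone.

In an assay on cells for inhibition of C-X-C chemokine receptor type 4 (Homo sapiens), with a stated time of 22 h, tested at 100 nM (a lower number here means less inhibition, a higher number more inhibition at the concentration tested (going by the name of the read-out)), compound 1 `O=C(NCc1ccc(CNS(=O)(=O)c2ccc3c(c2)CCO3)cc1)c1scc2c1OCCO2` gives 68%, compound 3 `O=C(NCc1ccc(CNS(=O)(=O)c2ccc3c(c2)CCO3)cc1)c1cccnc1` gives 60%, and compound 2 `Cc1cc(C(=O)NCc2ccc(CNS(=O)(=O)c3ccc4c(c3)CCO4)cc2)n(C)n1` is reported only as "active" (no number reported) without a number. The numbers for compound 3 and compound 1 sit within the usual scatter of each other, so compound 3 stands alongside compound 1 rather than apart from it. Compound 4 `Cn1nccc1C(=O)NCc1ccc(CNS(=O)(=O)c2ccc3c(c2)CCO3)cc1` differs from compound 3 in one place: 1-methyl-1H-pyrazol-5-yl in place of pyridin-3-yl on a carbonyl carbon. Among the compounds with values here, the only measured step at the carbonyl carbon, a number 8 percentage points lower from compound 1 to compound 3 (within the scatter), stayed within the scatter, and compound 2 offers no number to compare. Compound 4 is therefore expected to show no step beyond the scatter, a number 2 percentage points lower from compound 3 to compound 4 (within the scatter). In this assay compound 4 is estimated at 58%, with a range from 40% to 75%.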

Compound 4, a percentage reported as inhibition, at one concentration (the size of the read-out at that concentration, not a potency): 40%
Compound 4: the middle estimate sits 18 percentage points above what was measured; measured number inside the range.
By their numbers in this assay, from the lowest: compound 4; then compounds 3 and 1 (each within the scatter of the next).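

In this assay, the group on the carbonyl carbon can shift the read-out beyond the scatter: 1-methyl-1H-pyrazol-5-yl in place of pyridin-3-yl gives a number 20 percentage points lower from compound 3 to compound 4 (beyond the scatter), and the wider exchange gives a number 28 percentage points lower from compound 1 to compound 4 (beyond the scatter). The two groups in the first exchange hold the same count of heavy atoms, so that count does not separate them. Nothing given here accounts for the drop.

Steps involving compound 2 cannot be read, so the effect of the extra methyl on its pyrazole stays open. Also open, on these data alone, is how a plain phenyl or a saturated piperidin-4-yl on this carbonyl carbon would read.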